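Chloro for methoxy on the aryl group of compound 1

The source may report more compounds than this note shows. Statements on the series, on what has been measured and on what is new or still open speak of the compounds shown alone.

Measured so far:
compound 1, `COc1cccc(CCCC(=O)Nc2nc3ccccc3c(=O)s2)c1`, in an assay on membranes from brain for displacement of a labelled ligand from adenosine receptor A1 (Rattus norvegicus), read by scintillation counting, with a stated time of 90 min (a lower number here means a stronger inhibitor, a higher number a weaker inhibitor), gives 22.5 nM.
compound 2, `O=C(COc1cccc(Cl)c1)Nc1nc2ccccc2c(=O)s1`, gives > 10000 nM, which is a limit of the assay and not a number.

Among the compounds with values here, compound 1 is the only compound of the pair with a real number in this assay; the other value shown is a limit (the limit of > 10000 nM in this assay, at which 1 of the 2 values shown sits). Within the data shown here, compound 2 and compound 1 differ in more than one place, so their two values show only that compound 1 has a measurable inhibition constant and compound 2 does not.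

Compound 3, `O=C(CCCc1cccc(Cl)c1)Nc1nc2ccccc2c(=O)s1`, is not yet measured. It differs from compound 1 by chloro in place of methoxy on an aromatic carbon. Among the measured compounds shown here, no measured step bears on this exchange, so the expectation rests on compound 1 alone. The step in this assay is expected to be small, in the weaker direction if anywhere, and possibly not beyond the usual scatter. The expected step is a 1.8-fold higher number from compound 1 to compound 3 (0.25 log units; within the scatter). Compound 3 is expected at 40 nM, with a range from 10 nM to 200 nM.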

Compound 3, inhibition constant: 898 nM
Estimate against measurement, compound 3: 22-fold (1.35 log units) below; the measured number lies above the stated range.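

In this assay, within the data shown here, the exchange of 3-methoxyphenyl for 3-chlorophenyl is the only change in one place that can be read between two real numbers, and it gives a 40-fold higher number from compound 1 to compound 3 (1.60 log units; beyond the scatter). With the chain and the shared core held constant, this aromatic carbon is therefore sensitive to the group it carries, and chloro does not stand in for methoxy here, although compound 3 still has a measurable inhibition constant. Nothing shown gives a reason for the size of this step.

Compound 3 shares the 3-chlorophenyl group with compound 2. Compound 2 gives > 10000 nM, a limit and not a number, so the step between these two cannot be read. From the compounds shown here alone, it remains open whether the loss is particular to chloro or whether a hydroxyl, an ethoxy, a methyl, a fluoro or an amine on the same carbon would stay closer to compound 1, and whether the same exchange behaves alike on a shorter or longer chain.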